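Fluoro in Place of Hydroxy on an Aromatic Carbon

The source may report more compounds than this note shows. Statements on the series, on what has been measured and on what is new or still open speak of the compounds shown alone.

Going by the values given here, in a functional assay on HL-60 cells (Homo sapiens) for cytotoxicity, read by WST assay, with a stated time of 48 h (a lower number here means that less compound is needed, a higher number that more compound is needed for the effect), compound 1 (`O=C1OC[C@H](Cc2ccccc2F)[C@H]1Cc1ccc(Cl)c(Cl)c1`) gives 28000 nM and compound 2 (`O=C1OC[C@H](Cc2ccc(O)cc2)[C@H]1Cc1ccc(Cl)c(Cl)c1`) gives 37000 nM, so compound 2 stands within the scatter of its only measured neighbour. Compound 3 (`O=C1OC[C@H](Cc2ccc(F)cc2)[C@H]1Cc1ccc(Cl)c(Cl)c1`) carries fluoro in place of hydroxy on an aromatic carbon, para to a large group, 4-hydroxyphenyl to 4-fluorophenyl: fluoro in place of hydroxy on an aromatic carbon. Among the compounds with values here, the one measured step bearing on this, a 1.3-fold higher number from compound 1 to compound 2 (0.12 log units; within the scatter), exchanged 2-fluorophenyl for 4-hydroxyphenyl and stayed within the scatter, so no step beyond the scatter is expected in this assay. For compound 3 the estimated value is 30000 nM, with an expected range of 14000 nM to 62000 nM.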

Compound 3, half-maximal effective concentration: 14000 nM
For compound 3 the middle estimate is 2.1-fold (0.33 log units) above the measured one; low and high end bracket the measured number.
By their numbers in this assay, from the lowest: compounds 3, 1 and 2 (each within the scatter of the next, the first and the last beyond it).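

Fluoro in place of hydroxy gives a 2.6-fold lower number from compound 2 to compound 3 (0.42 log units; beyond the scatter) in this assay, the first step beyond the scatter in this series, though a modest one. Moving the fluoro, 2-fluorophenyl to 4-fluorophenyl, gives a 2.0-fold lower number from compound 1 to compound 3 (0.30 log units; within the scatter) and stays within the scatter, so these compounds do not separate the two places on the ring. Nothing available here explains the step from hydroxy to fluoro.

On these data alone, whether methoxy or an amine on this aromatic carbon would stand with hydroxy or with fluoro remains open. So does whether chloro would go further than fluoro.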